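This account rests on a few compounds, and the source may have more. Where it says the series, first, only, none or still open, it means among the compounds named here.

Measured in an ADME assay on HepG2 cells (Homo sapiens) for cytotoxicity, with a stated time of 72 h; on this read-out higher numbers stand for an effect only at larger amounts of compound and lower numbers for an effect already at smaller amounts:

- compound 1 `Cc1cc(NC(=O)Nc2cccc(F)c2)c2ccccc2n1` gives > 25000 nM (a limit)
- compound 2 `COc1cccc(NC(=O)Nc2cc(C)nc3ccccc23)c1` gives > 25000 nM (a limit)
- compound 3 `Cc1cc(NC(=O)Nc2cccc(Cl)c2)c2ccccc2n1` gives 19000 nM

For the measured compounds named here, compound 3 holds the only actual number in this small set, 19000 nM. The other two results stand at a limit of the assay, as shown by the limit of > 25000 nM in this assay, at which 2 of the 3 values shown sit. Compound 4 `Cc1cc(NC(=O)Nc2cccc(C(C)(C)C)c2)c2ccccc2n1` has tert-butyl in place of chloro on an aromatic carbon, (tert-butyl in place of chloro on an aromatic carbon). Going by the values given here, no measured compound carries tert-butyl, so the nearest guide is the other swaps on an aromatic carbon. These are an at least 1.3-fold lower number from compound 1 to compound 3 (0.11 log units; that floor lies within the scatter) and an at least 1.3-fold lower number from compound 2 to compound 3 (0.11 log units; that floor lies within the scatter). The third swap is a step that the two limits leave unreadable from compound 1 to compound 2. None of these swaps shows a change beyond the scatter in this assay, so no clear shift in either direction is expected. The expected step is no change at the digits printed from compound 3 to compound 4 (within the scatter). For compound 4 the estimated value is 19000 nM, with an expected range from 9000 nM to 40000 nM.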

Compound 4, half-maximal effective concentration: > 25000 nM
Compound 4 gave a limit, no number (the forecaster's own chance of this, stated with the estimate: 40%); middle value at least 1.3-fold (0.11 log units) from the limit.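

In this assay, tert-butyl in place of chloro on this aromatic carbon, meta to a large group, gives an at least 1.3-fold higher number from compound 3 to compound 4 (0.11 log units; that floor lies within the scatter). For the compounds shown here, compound 4 gives > 25000 nM, which is a limit, so the true size of this step stays unknown and chloro remains the only group at this position with an actual number. The steps to compound 4 from compound 1 and from compound 2 join two limits and cannot be read, and tert-butyl now stands with fluoro and methoxy at the same limit of the assay: the limit of > 25000 nM in this assay, at which 3 of the 4 values shown sit.

The compounds shown leave open whether any group at this position would give a number clearly apart from that of compound 3. On these data alone, an amine or a carboxylic acid on this aromatic carbon could test that, and what either would give remains unknown.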